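The compounds below may be only part of what the source reports. "The series", "measured", "known", "first", "only" and "open" are said of these compounds alone.

Working notes on the series. Compound 1 `O=C(CC(CC(=O)NC1Cc2ccccc2C1)c1ccc(Cl)cc1)NCCN1CCCCC1` and compound 3 `CCNCCNC(=O)CC(CC(=O)N(CC)C1Cc2ccccc2C1)c1ccc(Cl)cc1` have both been run in a functional assay on MGC-803 cells (Homo sapiens) for inhibition; on this read-out higher numbers stand for weaker inhibition and lower numbers for stronger inhibition. In this assay compound 1 gives 89100 nM. In this assay compound 3 gives 43800 nM, the lower of the two numbers, with compound 1 the nearest neighbour and the gap between them beyond the scatter. How the core of compound 1 and the core of compound 3 differ is not broken down here.

Compound 2 `O=C(CC(CC(=O)NC1Cc2ccccc2C1)c1ccccc1)NCCN1CCCCC1` differs from compound 1 by hydrogen in place of chloro on an aromatic carbon. For compound 2 this assay reports only a limit, > 100000 nM, which is the limit of > 100000 nM in this assay, at which 1 of the 3 values shown sits. The measured step is thus an at least 1.1-fold higher number from compound 1 to compound 2 (0.05 log units; that floor lies within the scatter), and only its floor is known.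

Compound 4 `CCNCCNC(=O)CC(CC(=O)N(CC)C1Cc2ccccc2C1)c1ccccc1` has not yet been measured in this assay. Going by the values given here, it differs from compound 3 by hydrogen in place of chloro on an aromatic carbon, the same change at the same place as the one taken from compound 1 to compound 2. The expected step is a 2.1-fold higher number from compound 3 to compound 4 (0.31 log units; beyond the scatter), resting on the earlier at least 1.1-fold higher number from compound 1 to compound 2 (0.05 log units; that floor lies within the scatter), whose true size may well be larger than its floor because compound 2 sits at the limit of > 100000 nM in this assay, at which 1 of the 3 values shown sits. Compound 4 is therefore expected to give about 90000 nM in this assay. The estimate for compound 4 is expected to span from 40000 nM to 250000 nM, with a real chance that this assay again reports only a limit.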

Compound 4, half-maximal inhibitory concentration: > 100000 nM
Compound 4: no number, only a limit; the forecaster's own chance of this, stated with the estimate: 40%; middle value at least 1.1-fold (0.04 log units) away from the limit.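

In this assay, replacing 4-chlorophenyl with phenyl on the core of compound 3 gives an at least 2.2-fold higher number from compound 3 to compound 4 (0.35 log units; beyond the scatter), so on this core the loss of the chloro group costs inhibition by a margin beyond the scatter, and the true step may be larger than this floor. Set beside the same change on the core of compound 1, this result is compatible with a step in the same direction on both cores, but the floor of the earlier step lies within the scatter and does not establish that direction on its own, and the two sizes cannot be ranked: the same change on two cores in this assay, an at least 1.1-fold higher number (0.05 log units; that floor lies within the scatter) from compound 1 to compound 2 and an at least 2.2-fold higher number (0.35 log units; beyond the scatter) from compound 3 to compound 4; the limit leaves it open whether they differ. Compound 2 and compound 4 both stop at the assay limit, so the series shows that the change can be carried across these two cores without any sign of a reversal, but it does not show how far the step transfers in size: the limit of > 100000 nM in this assay, at which 2 of the 4 values shown sit.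

The compounds shown leave open what other groups at this place on the aromatic ring would do, such as fluoro, methoxy or a nitrile in place of chloro. They also leave open whether the step holds on a core with a longer chain or a carboxylic acid in place of the amine.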